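Silicon for cyclopropyl on a sulfonamide chain

The compounds below may be only part of what the source reports. "The series", "measured", "known", "first", "only" and "open" are said of these compounds alone.

Compound 1 `CN[C@H](CNc1cc(F)c(S(=O)(=O)Nc2ncc(F)s2)cc1Cl)C[Si](C)(C)C` was tested in an ADME assay on HEK293 cells for inhibition of sodium channel protein type 8 subunit alpha (Homo sapiens), read by patch clamp, with a stated time of 5 min; on this read-out higher numbers stand for weaker inhibition and lower numbers for stronger inhibition. In this assay, for the measured compounds named here, compound 1 gives 3130 nM, the only number it has here, with one further entry that did not yield a single figure. Going by the values given here, compound 2 `CC1(CNc2cc(F)c(S(=O)(=O)Nc3nccs3)cc2Cl)CCCN1`, which carries a different amine portion on the shared core, gives 2080 nM; 860 nM (2 entries) in this assay, as the several entries of compound 2 show (the several entries of compound 2 in this assay, 2080 nM; 860 nM (2 entries)); no step between compound 1 and compound 2 is computed, so their values stand side by side without further comparison.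

Compound 3 `CN[C@H](CNc1cc(F)c(S(=O)(=O)Nc2ncc(F)s2)cc1Cl)CC1CC1` has not yet been measured in this assay. It differs from compound 1 in one place: a group of 3 heavy atoms (3 carbon; one three-membered non-aromatic ring of carbon only) in place of a group of 4 heavy atoms (3 carbon, 1 silicon; no ring), on a saturated chain carbon, two bonds along the chain from an amine nitrogen. Among the compounds with values here, no measured pair in this set isolates such a change, so the expectation rests on compound 1 alone. The step from compound 1 to compound 3 is expected to be small in this assay, toward weaker inhibition if anything, and possibly within the ordinary scatter, as a 1.4-fold higher number from compound 1 to compound 3 (0.16 log units; within the scatter) conveys. On that basis compound 3 is estimated at 4500 nM, with a plausible range from 1500 nM to 13000 nM.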

Compound 3, half-maximal inhibitory concentration: > 34000 nM
Compound 3 was reported as a limit; the forecaster's own chance of this, stated with the estimate: 10%; middle value at least 7.5-fold (0.87 log units) away from the limit.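

Compound 3 gives > 34000 nM in this assay, which is a limit of the assay and not a number. The earlier compounds shown here gave no hint that this position mattered so much: on a saturated chain carbon, two bonds along the chain from an amine nitrogen, putting cyclopropyl in place of the group of 4 heavy atoms that carries silicon produces an at least 10-fold higher number from compound 1 to compound 3 (1.03 log units; beyond the scatter), and the true size of the step may be larger still. Repeated entries of a single compound do differ, but by visibly less than this step: the several entries of compound 2 in this assay, 2080 nM; 860 nM (2 entries)

The compounds shown leave open whether the silicon itself or the open, ringless form of the departing group accounts for the difference, and a tert-butyl group at this place would separate those two readings. For the compounds shown here, this single pair also cannot tell whether the same exchange would have a comparable effect with another amine portion, such as the one in compound 2.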